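Trifluoromethylphenyl positional variation on the shared core

The source may hold more compounds than are shown below. What is called first, only, known or untested is meant among the compounds shown, and "the series" means these compounds.

Measured compounds, with their values in a functional assay on HeLa cells (Homo sapiens) for inhibition, read by MTT assay, with a stated time of 72 h; a higher number here means a weaker inhibitor, a lower number a stronger inhibitor:
compound 1, `CN(C(=O)NC(=O)c1cccc(C(F)(F)F)c1)c1nc(C(F)(F)F)c(C(=O)N/N=C/c2cccc(C(F)(F)F)c2)s1`: 4.81 ug/mL
compound 2, `CN(C(=O)NC(=O)c1cccc(C(F)(F)F)c1)c1nc(C(F)(F)F)c(C(=O)N/N=C/c2ccccc2C(F)(F)F)s1`: 7.37 ug/mL
compound 3, `CN(C(=O)NC(=O)c1cccc(C(F)(F)F)c1)c1nc(C(F)(F)F)c(C(=O)N/N=C/c2ccc(C(F)(F)F)cc2)s1`: 7.35 ug/mL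

Compound 2 gives the highest of the three numbers, but its neighbours sit close: compound 3 is a 1.0-fold lower number from compound 2 to compound 3 (0.00 log units; within the scatter), and compound 1 is a 1.5-fold higher number from compound 1 to compound 2 (0.19 log units; within the scatter). Across the three measured compounds the numbers therefore do not separate.

Compound 4, `CN(C(=O)NC(=O)c1ccc(C(F)(F)F)cc1)c1nc(C(F)(F)F)c(C(=O)N/N=C/c2ccccc2C(F)(F)F)s1`, is unmeasured. It differs from compound 2 as follows: 4-(trifluoromethyl)phenyl in place of 3-(trifluoromethyl)phenyl on a carbonyl carbon.

The three measured steps, a 1.5-fold higher number from compound 1 to compound 2 (0.19 log units; within the scatter), a 1.5-fold higher number from compound 1 to compound 3 (0.18 log units; within the scatter) and a 1.0-fold lower number from compound 2 to compound 3 (0.00 log units; within the scatter), all move the trifluoromethyl group between positions on the phenyl attached to the carbon with a double bond to nitrogen. Each stays within the scatter. Going by the values given here, no measured pair changes the phenyl on the carbonyl carbon, so nothing bears directly on the step to compound 4. The closest guide is that moving the same group on the other phenyl, in compounds 1, 2 and 3, gave no step beyond the scatter. For compound 4 no step beyond the scatter is therefore expected, a 1.1-fold lower number from compound 2 to compound 4 (0.02 log units; within the scatter). The estimate for compound 4 in this assay is 7 ug/mL, within a range of 3.5 ug/mL to 14 ug/mL.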

Compound 4, half-maximal inhibitory concentration: 3.76 ug/mL
Compound 4: middle estimate off by 1.9-fold (0.27 log units), on the high side; measured number inside the range.
By their numbers in this assay, from the lowest: compounds 4, 1, 3 and 2 (each within the scatter of the next).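

In this assay, going by these compounds alone, the phenyl on the carbonyl carbon now has a measured step of its own: 4-(trifluoromethyl)phenyl in place of 3-(trifluoromethyl)phenyl gives a 2.0-fold lower number from compound 2 to compound 4 (0.29 log units; within the scatter) and so stays within the scatter, like the earlier steps on the other phenyl. Taken alone, this step therefore separates neither compound from the other, and it gives no ground for ranking the two trifluoromethyl positions at this site. The new information lies in the comparison of two steps, which shows that within these compounds the same replacement does not read the same way on the carbonyl carbon as on the carbon with a double bond to nitrogen, although neither step is beyond the scatter by itself: the same change on two cores in this assay, a 1.5-fold higher number (0.18 log units; within the scatter) from compound 1 to compound 3 and a 2.0-fold lower number (0.29 log units; within the scatter) from compound 2 to compound 4, 3.0-fold (0.48 log units) apart, beyond the scatter of two such steps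

As far as these compounds go, this rests on one step at each site, so it remains open whether the gap holds with the other phenyl partners on the shared core, including 2-(trifluoromethyl)phenyl on the carbonyl carbon. The compounds shown also leave open how a phenyl carrying a nitrile, a carboxylic acid or an amine in place of trifluoromethyl would behave on the carbonyl carbon.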